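The source may hold more compounds than are shown below. What is called first, only, known or untested is meant among the compounds shown, and "the series" means these compounds.

Measured in a functional assay on HL-60 cells (Homo sapiens) for antiproliferative activity, read by MTT assay, with a stated time of 72 h; on this read-out higher numbers stand for weaker inhibition and lower numbers for stronger inhibition:
- compound 1 `COc1cc(-c2ncnn2-c2ccc(Cl)cc2Cl)cc(OC)c1OC`: > 10000 nM, a limit
- compound 2 `COc1cc(-c2ncnn2-c2ccc(F)cc2)cc(OC)c1OC`: > 10000 nM, a limit
- compound 3 `COc1cc(-c2ncnn2-c2ccc([N+](=O)[O-])cc2)cc(OC)c1OC`: > 10000 nM, a limit

Compound 3 has no numerical value, only a limit, and the other two compounds offer no number either. Compound 4 `COc1cc(-c2ncnn2-c2ccc(Cl)cc2)cc(OC)c1OC` carries chloro in place of nitro on an aromatic carbon. The nearest measured change is a step that the two limits leave unreadable from compound 2 to compound 3, at the same place on the ring. The other is a step that the two limits leave unreadable from compound 1 to compound 2. Neither gives a size to carry over. Because of the limit of > 10000 nM in this assay, at which 3 of the 3 values shown sit, no gain beyond the scatter is expected, and this assay will probably report a limit again. The expected step is a step that the limit leaves unreadable from compound 3 to compound 4. For compound 4 the estimated value is 12000 nM, with an expected range from 5000 nM to 30000 nM.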

Compound 4, half-maximal inhibitory concentration: > 10000 nM
Compound 4: no number, only a limit (the forecaster's own chance of this, stated with the estimate: 80%); the middle value is on the limit's open side.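

In this assay the steps from compound 1, compound 2 and compound 3 to compound 4 cannot be read, since all four compounds sit at the same limit: the limit of > 10000 nM in this assay, at which 4 of the 4 values shown sit.

The compounds shown leave open which change on the shared core, if any, would give a measurable value.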